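Removing the acetyl from compound 2: expected effect

This account rests on a few compounds, and the source may have more. Where it says the series, first, only, none or still open, it means among the compounds named here.

Among the measured compounds shown here, only two compounds carry a number so far. Compound 1 `Cc1c(OC2CCN(C)CC2)ccc2cc(NC(=O)c3ccc4c(c3)CCC(C)(C)O4)c(=O)oc12` gives 5010 nM in a functional assay on MCF7 cells (Homo sapiens) for antiproliferative activity; a higher number here means a weaker inhibitor, a lower number a stronger inhibitor. Compound 2 `C=CCc1cc(C(=O)Nc2cc3ccc(OC4CCN(C)CC4)c(C)c3oc2=O)ccc1OC(C)=O` gives 2000 nM in this assay, the lower of the two numbers, and the gap to compound 1 lies beyond the scatter. Compound 3 `C=CCc1cc(C(=O)Nc2cc3ccc(OC4CCN(C)CC4)c(C)c3oc2=O)ccc1O` has not yet been measured in this assay. It differs from compound 2 in one place: hydrogen in place of acetyl on an oxygen on an aromatic ring. For the measured compounds named here, no pair of measured compounds shows what hydrogen in place of acetyl on an oxygen on an aromatic ring does, so the expectation rests on the small size of the change alone. The step of a 1.3-fold lower number from compound 2 to compound 3 (0.12 log units; within the scatter) is expected to be modest, toward a lower number if anything, and may not exceed the scatter. The estimate for compound 3 in this assay is 1500 nM, with a range from 500 nM to 4500 nM.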

Compound 3, half-maximal inhibitory concentration: 2170 nM
Beside the measured number, compound 3's estimate is 1.4-fold (0.16 log units) below it; the range from low to high includes it.
By their numbers in this assay, from the lowest: compounds 2 and 3 (each within the scatter of the next); then compound 1.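

In this assay, among the compounds shown here, the acetoxy to hydroxy change gives a 1.1-fold higher number from compound 2 to compound 3 (0.04 log units; within the scatter), the first reading of this change. On this oxygen on an aromatic ring, acetyl and hydrogen are therefore not told apart by this read-out, even though three heavy atoms leave. This holds for this one pair only, and nothing measured here offers an explanation for the flat step.

As far as these compounds go, whether a methyl ether, a longer acyl chain or an amine in place of the hydroxy would move the number beyond the scatter remains open. For the compounds shown here, also open is whether the same flat step would hold with an amide part other than the one shared by compound 2 and compound 3.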